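The compounds below may be only part of what the source reports. "The series", "measured", "known", "first", "only" and "open" are said of these compounds alone.

Among the measured compounds shown here, compound 2 `COc1ccc(Nc2cc(-c3ccccc3)oc(=O)c2)cc1` is the only compound with a numeric result in a functional assay on SK-BR-3 cells (Homo sapiens) for cytotoxicity, read by MTT assay, with a stated time of 72 h; a lower number here means that less compound is needed, a higher number that more compound is needed for the effect: compound 2 gives 0.079 uM. Compound 1 `COc1ccc(Nc2cc(C(C)C)oc(=O)c2)cc1` is known in this assay only by a limit, where compound 1 gives > 30 uM. The change of phenyl in place of isopropyl on an aromatic carbon therefore appears as an at least 370-fold lower number from compound 1 to compound 2 (2.57 log units; beyond the scatter), a size that rests on (the limit of > 30 uM in this assay, at which 1 of the 2 values shown sits). Compound 3 `COc1ccc(Nc2cc(C3CCCC3)oc(=O)c2)cc1` carries the change (cyclopentyl in place of phenyl on an aromatic carbon). Cyclopentyl is a five-membered non-aromatic ring of carbon only, and the single measured step shows that the phenyl at this aromatic carbon is what brought the number down from compound 1 to compound 2. Removing that phenyl in favour of a non-aromatic ring is therefore expected to push the number back up, and compound 3 is expected to show a 100-fold higher number from compound 2 to compound 3 (2.01 log units; beyond the scatter). Compound 3 is estimated at 8 uM, within a range from 1 uM to 40 uM.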

Compound 3, concentration for half-maximal effect: 4.73 uM
For compound 3 the middle estimate is 1.7-fold (0.23 log units) above the measured one; low and high end bracket the measured number.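

At this position, on an aromatic carbon next to the ring oxygen, a non-aromatic ring does not take the place of phenyl: in this assay, cyclopentyl in place of phenyl gives a 60-fold higher number from compound 2 to compound 3 (1.78 log units; beyond the scatter). Aromatic phenyl is still not the only group here that lowers the number, since cyclopentyl in place of isopropyl gives an at least 6.3-fold lower number from compound 1 to compound 3 (0.80 log units; beyond the scatter). Going by these compounds, the real size of this last step stays unknown, and it can be stated only against a limit: the limit of > 30 uM in this assay, at which 1 of the 3 values shown sits.

The compounds shown leave open whether a pyridine ring at this carbon would keep the low number of phenyl, or whether a cyclohexyl ring would move the number in either direction. They also leave open how a fluorine or a methoxy group on the phenyl itself would change the result.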